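The source may hold more compounds than are shown below. What is called first, only, known or untested is meant among the compounds shown, and "the series" means these compounds.

Measured in an ADME assay on microsomes from liver (Homo sapiens) for metabolic stability, read by LC-MS, with NADPH named in the record, with a stated time of 60 min, tested at 1 uM, in the absence of a further agent; a higher number here means that more of the compound is left, a lower number that less of the compound is left:

compound 1 `COc1ccc(-n2c(C)nc3c(N4CC[C@@H](NC(C)=O)C4)nc(C)nc32)cc1OC`: > 95%, a limit of the assay
compound 2 `COc1ccc(-c2c(C)sc3c(N4CC[C@@H](NC(C)=O)C4)nc(C)nc23)cc1OC`: > 95%, a limit of the assay
compound 3 `COc1ccc(-c2c(C)nc3c(N4CC[C@@H](NC(=O)C(F)(F)F)C4)cc(C)nn23)cc1OC`: > 95%, a limit of the assay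

Compound 3 thus stands at the upper limit of this assay rather than at a number. Going by the values given here, the same holds for the other two values, since (the limit of > 95% in this assay, at which 3 of the 3 values shown sit); no measured value lies below that limit, and no step between two measured compounds is available, so the series gives no measured size for any change.

Compound 4 `COc1ccc(-c2c(C)nc3c(N4CC[C@@H](NS(=O)(=O)c5ccccc5)C4)cc(C)nn23)cc1OC` differs from compound 3 in one place: phenylsulfonyl in place of (trifluoromethyl)carbonyl on an amine nitrogen. The rest of the structure is kept.

With every measured value sitting at the limit, the expectation for the step from compound 3 to compound 4 is that a number at least 5 percentage points lower from compound 3 to compound 4 (that floor lies within the scatter) stays within the scatter, that is, no change beyond it. Compound 4 is therefore estimated at 90%, with a range from 70% to 98%, and a fair chance that this assay again reports only the limit.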

Compound 4, percent of the compound remaining: > 95%
Compound 4: a limit, no number (the forecaster's own chance of this, stated with the estimate: 55%); at least 5 percentage points between middle value and limit.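

The step from compound 3 to compound 4 cannot be read in this assay, as both values are limits of the assay: the limit of > 95% in this assay, at which 4 of the 4 values shown sit.

The compounds shown leave open whether phenylsulfonyl and (trifluoromethyl)carbonyl on this amine nitrogen differ at all in the percent of compound remaining.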